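This account rests on a few compounds, and the source may have more. Where it says the series, first, only, none or still open, it means among the compounds named here.

Measured so far:
compound 1, `c1cc(-c2cn[nH]c2)c2c(c1)C(c1ncc[nH]1)CC2`: 14 nM in a functional assay on CHO cells for agonist activity at Alpha-1A adrenergic receptor (Homo sapiens), read by FLIPR and calcium flux; a higher number here means that more compound is needed for the effect, a lower number that less compound is needed
compound 2, `CNC(=O)c1cccc2c1CCC2c1ncc[nH]1`: 2200 nM in this assay

Among the measured compounds shown here, compound 2 gives the highest number of the two, and its only neighbour is compound 1. For the measured compounds named here, the single measured step is a 160-fold higher number from compound 1 to compound 2 (2.20 log units; beyond the scatter). Compound 3, `c1cc(-c2ccn[nH]2)c2c(c1)C(c1ncc[nH]1)CC2`, is not yet measured; it differs from compound 2 by 1H-pyrazol-5-yl in place of methylcarbamoyl on an aromatic carbon. That one step bears directly on this change, because a 160-fold higher number from compound 1 to compound 2 (2.20 log units; beyond the scatter) came from exchanging a pyrazole for methylcarbamoyl. Restoring a pyrazole, even though 1H-pyrazol-5-yl is not the 1H-pyrazol-4-yl of compound 1, is expected to give a large drop, a 63-fold lower number from compound 2 to compound 3 (1.80 log units; beyond the scatter). Compound 3 is therefore estimated at 35 nM, within 8 nM to 200 nM.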

Compound 3, half-maximal effective concentration: 52 nM
For compound 3 the middle estimate is 1.5-fold (0.17 log units) below the measured one; low and high end bracket the measured number.
By their numbers in this assay, from the lowest: compound 1; then compound 3; then compound 2.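

Putting a pyrazole back on this aromatic carbon in place of methylcarbamoyl recovers most of the lost ground, with a 42-fold lower number from compound 2 to compound 3 (1.63 log units; beyond the scatter) as the result. How the pyrazole is attached also matters, though less, since 1H-pyrazol-5-yl in place of 1H-pyrazol-4-yl gives a 3.7-fold higher number from compound 1 to compound 3 (0.57 log units; beyond the scatter) on the same carbon. No available evidence explains either step.

As far as these compounds go, whether the low numbers require a pyrazole at all remains open. A phenyl ring, a thiazole or a simple amine on this same aromatic carbon could help to answer that.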